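From nitro to trifluoromethyl on the shared core

The source may report more compounds than this note shows. Statements on the series, on what has been measured and on what is new or still open speak of the compounds shown alone.

In an ADME assay on H9c2 cells (Rattus norvegicus) for cytotoxicity (a higher number here means a weaker inhibitor, a lower number a stronger inhibitor), compound 1 `CC(C)(C)c1ccc2nc(NC(=O)C3CC3)sc2c1` gives 32000 nM as a measured value. Compound 2 `O=C(Nc1nc2ccc([N+](=O)[O-])cc2s1)C1CC1` gives > 50000 nM and that is a limit of the assay, not a number. Compound 3 `O=C(Nc1nc2ccc(C(F)(F)F)cc2s1)C1CC1` carries trifluoromethyl in place of nitro on an aromatic carbon and has not yet been measured. Going by the values given here, the one measured step that bears on this change is an at least 1.5-fold higher number from compound 1 to compound 2 (0.19 log units; that floor lies within the scatter) and it is the only guide available. No step beyond the scatter is therefore expected in this assay for this change. The estimated step is an at least 1.2-fold lower number from compound 2 to compound 3 (0.09 log units; that floor lies within the scatter) in this assay overall. Compound 3 is expected at 40000 nM within an estimated range of 20000 nM to 70000 nM in this assay here.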

Compound 3, half-maximal inhibitory concentration: > 50000 nM
Compound 3 gave a limit, no number (the forecaster's own chance of this, stated with the estimate: 40%); at least 1.2-fold (0.09 log units) between middle value and limit.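

In this assay, trifluoromethyl in place of tert-butyl gives an at least 1.5-fold higher number from compound 1 to compound 3 (0.19 log units; that floor lies within the scatter), so a second group on this aromatic carbon now shows the same floor that nitro showed. The step from nitro to trifluoromethyl cannot be read, because compound 2 and compound 3 both stand at a limit: the limit of > 50000 nM in this assay, at which 2 of the 3 values shown sit. Compound 3 thus shows that such a limit at this position is not confined to nitro, though no order among the three compounds follows. As far as these compounds go, whether an amine, a carboxylic acid or a longer chain at this position would give a measured number in this assay stays open.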